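A few compounds are considered here, and "the series" means these few. Any claim that something is new, unique, unknown or untested is made for them only; others in the source may bear on it.

Working notes on the series.

Compound 2 `CC(=O)c1ccc(OCc2ccc(C(F)(F)F)cc2)cc1` gives 26.4% in an assay on isolated protein for inhibition of Amine oxidase [flavin-containing] A (Homo sapiens), read by Amplex Red, with a stated time of 15 min, tested at 100 uM; a lower number here means less inhibition, a higher number more inhibition at the concentration tested (going by the name of the read-out). Compound 1 `CC(=O)c1ccc(OCc2ccc([N+](=O)[O-])cc2)cc1` differs from it by nitro in place of trifluoromethyl on an aromatic carbon and gives 33.8% in this assay; the step of a number 7.4 percentage points higher from compound 2 to compound 1 (within the scatter). Compound 3 `CC(=O)c1cccc(OCc2cccc(C(F)(F)F)c2)c1` holds the same atoms as compound 2 joined differently; the difference between the two cores is not broken down here. In this assay compound 3 gives 46.7%, the highest of the three numbers, beyond the scatter from both others.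

Compound 4 `CC(=O)c1cccc(OCc2cccc([N+](=O)[O-])c2)c1` is not yet measured. It differs from compound 3 by nitro in place of trifluoromethyl on an aromatic carbon. This is the same kind of change as from compound 2 to compound 1, though the place differs: para to a large group there, meta to a large group here. Going by the values given here, the step from compound 3 to compound 4 in this assay is expected to be about a number 4.3 percentage points higher from compound 3 to compound 4 (within the scatter), resting on the one earlier step of a number 7.4 percentage points higher from compound 2 to compound 1 (within the scatter) and its being within the scatter. Compound 4 is thus estimated at 51% in this assay, between 36% and 66%.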

Compound 4, a percentage reported as inhibition, at one concentration (the size of the read-out at that concentration, not a potency): 17.8%
Compound 4: the middle estimate sits 33.2 percentage points above what was measured; measured number below the stated range.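

In this assay the step is a number 28.9 percentage points lower from compound 3 to compound 4 (beyond the scatter), and nitro in place of trifluoromethyl does not behave alike on the two cores: the same change on two cores in this assay, a number 7.4 percentage points higher (within the scatter) from compound 2 to compound 1 and a number 28.9 percentage points lower (beyond the scatter) from compound 3 to compound 4, 36.3 percentage points apart, beyond the scatter of two such steps

The step on one core is therefore no guide to the same change on the other. With one pair per core, the data do not show which feature of the core accounts for the difference, or how the change would run on a further core.

The compounds shown leave open how other groups at the same place, such as an amine, a nitrile or a carboxylic acid, would read on either core. Also open, going by these compounds, is whether a longer chain in place of the ether link would alter the picture.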